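Hydroxy addition in a benzothiazolyl-thio anilide series

The source may hold more compounds than are shown below. What is called first, only, known or untested is meant among the compounds shown, and "the series" means these compounds.

The shared core of compound 1 `O=C(Nc1ccc(Sc2nc3ccccc3s2)cc1)c1cc(Br)cc(Br)c1O`, compound 2 `O=C(Nc1ccc(Sc2nc3ccccc3s2)c(Cl)c1)c1cccc(Br)c1O` and compound 3 `O=C(Nc1ccc(Sc2nc3ccccc3s2)c(Cl)c1)c1cc(Br)cc(Br)c1` is tested in an assay on isolated protein for inhibition of thiosulfate sulfurtransferase (Homo sapiens), with a stated time of 60 min, in the absence of a further agent; a lower number here means a stronger inhibitor, a higher number a weaker inhibitor. In this assay compound 1 gives only a limit, > 100000 nM. Compound 2 likewise gives only a limit in this assay, > 100000 nM. Compound 3 stands at the same limit in this assay, > 100000 nM. For the measured compounds named here, the one measured step, a step that the two limits leave unreadable from compound 2 to compound 3, is therefore not readable, since both ends sit at the limit; the only evidence is the limit of > 100000 nM in this assay, at which 3 of the 3 values shown sit.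

Compound 4 `O=C(Nc1ccc(Sc2nc3ccccc3s2)c(Cl)c1)c1cc(Br)cc(Br)c1O` differs from compound 3 by hydroxy in place of hydrogen on an aromatic carbon. Going by the values given here, no measured step shows the effect of adding a hydroxy on this carbonyl-side ring, and compound 1, which already carries a 3,5-dibromo-2-hydroxyphenyl, is at the limit as well. No movement beyond the scatter is expected in this assay, so the step that the limit leaves unreadable from compound 3 to compound 4 is estimated as essentially nil. Compound 4 is expected to remain at or beyond the limit in this assay, estimated at 200000 nM within 50000 nM to 1000000 nM.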

Compound 4, half-maximal inhibitory concentration: > 100000 nM
Compound 4: no number, only a limit; the forecaster's own chance of this, stated with the estimate: 85%; the middle value lies beyond the limit too.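

In this assay compound 4 gives > 100000 nM as a limit only. Its steps from compound 1, compound 2 and compound 3 therefore cannot be read: the limit of > 100000 nM in this assay, at which 4 of the 4 values shown sit.

The compounds shown leave open whether any change to the shared core gives a number rather than a limit in this assay at all.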